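The source may report more compounds than this note shows. Statements on the series, on what has been measured and on what is new or still open speak of the compounds shown alone.

Of the compounds shown here, three with a shared core have been measured in an assay on HEK293 cells for agonist activity at Toll-like receptor 8 (Homo sapiens), read by a luciferase reporter, with a stated time of 6 h; a higher number here means that more compound is needed for the effect, a lower number that less compound is needed. Compound 1 `CCCCNc1nc(N)nc2c1CNCC2` gives 7.2 uM. Compound 2 `CCCCNc1nc(N)nc2c1CN(Cc1ccccc1Cl)CC2` gives 0.05 uM, and compound 3 `CCCCNc1nc(N)nc2c1CN(Cc1ccc(OC)cc1)CC2` gives 0.08 uM. Compound 3 stands second highest of the three numbers: its nearest neighbour is compound 2, and a 1.6-fold higher number from compound 2 to compound 3 (0.20 log units; within the scatter) lies within the scatter, so the two cannot be told apart; its furthest neighbour is compound 1, whose value is far higher, and the two values are clearly separated.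

Compound 4 `CCCCNc1nc(N)nc2c1CN(Cc1ccccn1)CC2` is the next analog. pyridin-2-yl in place of 4-methoxyphenyl on a saturated chain carbon bound to an amine nitrogen in a ring

Within the data shown here, two measured steps bear on this. The step of a 140-fold lower number from compound 1 to compound 2 (2.16 log units; beyond the scatter) shows that the group on the amine nitrogen in the ring matters a great deal. The step of a 1.6-fold higher number from compound 2 to compound 3 (0.20 log units; within the scatter) shows that exchanging one six-membered aromatic ring for another at this place gave a change within the scatter. Compound 4 keeps a six-membered aromatic ring at the same place, so the step in this assay is expected to be small, in no clear direction. The expected step of a 1.3-fold higher number from compound 3 to compound 4 (0.10 log units; within the scatter) should stay within the scatter. For compound 4 the estimated value in this assay is 0.1 uM, with a range from 0.03 uM to 0.4 uM.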

Compound 4, minimum effective concentration: 0.07 uM
Beside the measured number, compound 4's estimate is 1.4-fold (0.15 log units) above it; measured number inside the range.
By their numbers in this assay, from the lowest: compounds 2, 4 and 3 (each within the scatter of the next); then compound 1.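

In this assay the aromatic ring at this place need not be of carbon only: pyridin-2-yl in place of 4-methoxyphenyl gives a 1.1-fold lower number from compound 3 to compound 4 (0.06 log units; within the scatter) and pyridin-2-yl in place of 2-chlorophenyl gives a 1.4-fold higher number from compound 2 to compound 4 (0.15 log units; within the scatter), so a ring with a hetero atom cannot be told apart from either carbon ring. Among these compounds, the large effect of filling the amine nitrogen in the ring also holds without a chlorine or a methoxy group on the new ring, as a 100-fold lower number from compound 1 to compound 4 (2.01 log units; beyond the scatter) is a step of the same large kind as the one to compound 2. Nothing measured here explains why these three different rings give such similar numbers.

Among the compounds shown here, every group at this place so far is a six-membered aromatic ring on a saturated chain carbon, so it remains open whether a cyclohexyl ring, a thiophene ring or a plain butyl chain would serve as well. From the compounds shown here alone, it also remains open how pyridin-3-yl or pyridin-4-yl would compare with pyridin-2-yl, and whether a ring carrying a carboxylic acid or an amine would keep numbers like these.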